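This account rests on a few compounds, and the source may have more. Where it says the series, first, only, none or still open, it means among the compounds named here.

In a functional assay on KB cells (Homo sapiens) for inhibition, read by sulforhodamine B assay (on this read-out higher numbers stand for weaker inhibition of growth and lower numbers for stronger inhibition of growth), compound 1 `COc1cc(-c2ccc(-c3ccc(-c4nc5cc(C)ccc5[nH]4)cc3)cc2)cc(OC)c1OC` gives 2110 nM and compound 2 `CN(C)c1ccc(-c2ccc(-c3ccc(-c4nc5ccccc5[nH]4)cc3)cc2)cc1` gives 39300 nM while compound 3 `Oc1cccc2[nH]c(-c3ccc(-c4ccc(-c5ccccc5)cc4)cc3)nc12` gives 4010 nM on the same read-out. Compound 3 thus lies within the scatter of compound 1 and well below compound 2, a gap beyond the scatter. Compound 4 `Oc1cccc2[nH]c(-c3ccc(-c4ccc(-c5cccc(Cl)c5)cc4)cc3)nc12` differs from compound 3 by the change chloro in place of hydrogen on an aromatic carbon that puts chloro in place of hydrogen on an aromatic carbon, meta to a large group. Among the compounds with values here, no measured pair shows this change, so the size of the step remains open. In this assay a small move toward stronger inhibition of growth is expected, with the estimated 1.4-fold lower number from compound 3 to compound 4 (0.16 log units; within the scatter) staying within the scatter. Compound 4 is estimated at 2800 nM with a range from 900 nM to 8000 nM as the expected span.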

Compound 4, concentration for 50% growth inhibition: 2280 nM
Compound 4: the middle estimate sits 1.2-fold (0.09 log units) above what was measured; the range from low to high includes it.
By their numbers in this assay, from the lowest: compounds 1, 4 and 3 (each within the scatter of the next); then compound 2.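

Going from phenyl to 3-chlorophenyl, the one step measured at this place, gives in this assay a 1.8-fold lower number from compound 3 to compound 4 (0.25 log units; within the scatter), so this aromatic carbon, meta to a large group, carries chloro with no change that can be told from the scatter. No measurement shown accounts for the size of this step. Going by these compounds, whether an amine, a carboxylic acid or a longer chain on this same carbon would give a step beyond the scatter stays open. So does whether chloro on another carbon of this ring would read the same.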